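The source may hold more compounds than are shown below. What is called first, only, known or untested is meant among the compounds shown, and "the series" means these compounds.

Compound 1 `Nc1ncnc2c1ncn2[C@H]1C[Se][C@@H](CO)O1`: in a functional assay on CCRF-CEM cells (Homo sapiens) for cytotoxicity (on this read-out higher numbers stand for weaker inhibition and lower numbers for stronger inhibition), compound 1 gives > 100000 nM, which is a limit of the assay and not a number.
Compound 2 `OC[C@H]1O[C@@H](n2cnc3c(O)ncnc32)C[Se]1`: in this assay compound 2 gives > 100000 nM, again a limit of the assay.

Compound 2 therefore stands only at a limit, with no measured number of its own. The step that the two limits leave unreadable from compound 1 to compound 2, hydroxy in place of amino on an aromatic carbon, is unreadable in size because both of its ends sit at the limit of > 100000 nM in this assay, at which 2 of the 2 values shown sit. Compound 3 `Nc1nc(O)c2ncn([C@H]3C[Se][C@@H](CO)O3)c2n1` differs from compound 2 by amino in place of hydrogen on an aromatic carbon. Within the data shown here, the only measured step bears on this change just by showing that both neighbours of compound 3 on the shared core sit at the limit, so no direction and no size can be read from it. Compound 3 is consequently expected to remain at the limit as well, with an expected step of a number no higher from compound 2 to compound 3 (the limit leaves the size open) to compound 3 and an estimated value for compound 3 of 100000 nM, within 30000 nM to 300000 nM.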

Compound 3, half-maximal inhibitory concentration: > 100000 nM
Compound 3 gave a limit, no number; the forecaster's own chance of this, stated with the estimate: 80%; the middle value sits exactly at the limit.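

Compound 2 and compound 3 both stand only at a limit in this assay and not at a number, so no new step can be read between them: the limit of > 100000 nM in this assay, at which 3 of the 3 values shown sit. The compounds shown leave open whether any change on the shared core shifts this read-out at all, and how far.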